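The compounds below may be only part of what the source reports. "The series", "measured", "known", "first", "only" and "open" are said of these compounds alone.

Within the data shown here, compound 1 `CC(C)(CCCCOc1cc(-c2ccccc2)c2ccccc2n1)C(=O)O` gives 183 nM in an assay on membranes from spleen (Cavia porcellus) for binding affinity to leukotriene B4 receptor 1 (Homo sapiens) (on this read-out lower numbers stand for stronger inhibition and higher numbers for weaker inhibition), and stands highest of the two numbers measured so far. Compound 2 `CC(C)(CCCCOc1cc(-c2ccc(Cl)cc2)c2ccccc2n1)C(=O)O` gives 15 nM in this assay; the step of a 12-fold lower number from compound 1 to compound 2 (1.09 log units; beyond the scatter) is the only one recorded in the series. Compound 3 `CC(C)(CCCCOc1cc(-c2ccccc2)c2cc(Cl)ccc2n1)C(=O)O` differs from compound 1 by chloro in place of hydrogen on an aromatic carbon. Among the measured compounds shown here, the single measured step bears on it only loosely, since its chloro sits on the other ring of the shared core, so a smaller drop than that of compound 2 is expected, with wide uncertainty. For compound 3 in this assay the estimate is 80 nM (range 25 nM to 250 nM), an expected step of a 2.3-fold lower number from compound 1 to compound 3 (0.36 log units; beyond the scatter).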

Compound 3, half-maximal inhibitory concentration: 2500 nM
Estimate against measurement, compound 3: 31-fold (1.49 log units) below; the measured number lies above the stated range.
By their numbers in this assay, from the lowest: compound 2; then compound 1; then compound 3.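

In this assay chloro in place of hydrogen on an aromatic carbon of the fused system gives a 14-fold higher number from compound 1 to compound 3 (1.14 log units; beyond the scatter) whereas the chloro of compound 2 gives a 12-fold lower number from compound 1 to compound 2 (1.09 log units; beyond the scatter) so the same exchange moves the number in opposite directions. For these two compounds, the direction of the change therefore depends on where the chloro sits. Nothing on hand accounts for this reversal. Still open, from the compounds shown here alone, is whether the loss at this position is specific to chloro or would also follow from fluoro, methyl or methoxy there.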